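The compounds below may be only part of what the source reports. "The series", "measured", "known", "first", "only" and "open" are said of these compounds alone.

Compound 1 `Cc1c(C(N)=O)sc2nc(NN)n(Cc3ccccc3)c(=O)c12` and compound 2 `Cc1cc(C)n(-c2nc3sc(C(N)=O)c(C)c3c(=O)n2Cc2ccccc2)n1` share one core and differ at a single aromatic carbon. In a functional assay on the whole organism (strain albino) for inhibition, with Rattus norvegicus as the target, with a stated time of 1 h, at a dose of 10 mg/kg by the oral route (on this read-out higher numbers stand for more inhibition at the one dose given (going by the name of the read-out) and lower numbers for less inhibition), compound 1 gives 44.8%, and in this assay compound 2 gives 40.3%. Among the measured compounds shown here, the one measured step, a number 4.5 percentage points lower from compound 1 to compound 2 (within the scatter), lies within the scatter, so compound 2 stands on the lower of the two numbers without being separable from compound 1. Compound 3 `CC1=NN(c2nc3sc(C(N)=O)c(C)c3c(=O)n2Cc2ccccc2)C(=O)C1` carries the next change at that same aromatic carbon: a group of 7 heavy atoms (4 carbon, 2 nitrogen, 1 oxygen; one five-membered non-aromatic ring with 2 hetero atoms) in place of a group of 7 heavy atoms (5 carbon, 2 nitrogen; one five-membered aromatic ring with 2 hetero atoms), on an aromatic carbon. For the measured compounds named here, no measured step exchanges an aromatic five-membered ring for a non-aromatic one, so the expectation rests only on the fact that the single exchange at this carbon, a number 4.5 percentage points lower from compound 1 to compound 2 (within the scatter), stayed within the scatter. The estimated step in this assay is a number 2.3 percentage points lower from compound 2 to compound 3 (within the scatter), none beyond the scatter. Compound 3 is therefore expected at 38%, with a range from 18% to 58%.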

Compound 3, a percentage reported as inhibition, in the whole organism at one dose (the size of the read-out at that dose, not a potency): 38.9%
Compound 3: middle estimate off by 0.9 percentage points, on the low side; measured number inside the range.
By their numbers in this assay, from the lowest: compounds 3, 2 and 1 (each within the scatter of the next).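

In this assay, the exchange of the aromatic 3,5-dimethyl-1H-pyrazol-1-yl for a five-membered non-aromatic ring with a carbonyl gives a number 1.4 percentage points lower from compound 2 to compound 3 (within the scatter), so at this aromatic carbon between two ring nitrogen atoms the read-out does not separate the two rings. Set against the open-chain group of compound 1, the same non-aromatic ring gives a number 5.9 percentage points lower from compound 1 to compound 3 (within the scatter), so all three groups shown, with or without a ring, remain within the scatter of one another. No data are at hand that would explain this at the one dose given.

Going by these compounds, all three groups join this carbon through nitrogen, so it remains open whether a phenyl ring or a methoxy group would shift the inhibition beyond the scatter. On these data alone, how the compounds compare at other doses also remains open.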